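Fluorine on the sulfanyl phenyl ring and unchanged inhibition

A few compounds are considered here, and "the series" means these few. Any claim that something is new, unique, unknown or untested is made for them only; others in the source may bear on it.

Measured in an assay on isolated protein for inhibition of Ca2+/calmodulin-dependent protein kinase II (CaM kinase II) (Rattus norvegicus), tested at 30 uM; on this read-out lower numbers stand for less inhibition and higher numbers for more inhibition at the one concentration tested (going by the name of the read-out):
Compound 1, `c1ccc(Sc2ncnc3[nH]cnc23)cc1`: 0%
Compound 2, `Fc1ccc(Sc2ncnc3[nH]cnc23)cc1`: 0%
Compound 3, `Fc1ccc(Cn2cnc3c(Sc4ccccc4)ncnc32)cc1`: 0%

All three measured compounds sit at the same level in this assay, and none shows inhibition at the digits reported. Compound 2 differs from compound 1 by fluoro in place of hydrogen on an aromatic carbon; the step is no change at the digits printed from compound 1 to compound 2 (within the scatter). Compound 3 has a different core: it differs from compound 1 by 4-fluorobenzyl in place of hydrogen on an aromatic nitrogen, and that step is no change at the digits printed from compound 1 to compound 3 (within the scatter).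

Compound 4, `Fc1ccc(Cn2cnc3c(Sc4ccc(F)cc4)ncnc32)cc1`, has not yet been measured. It differs from compound 3 by fluoro in place of hydrogen on an aromatic carbon. This is the same change, at the same place, as the one from compound 1 to compound 2; among the compounds shown it occurs twice. For compound 4 in this assay a step of no change at the digits printed from compound 3 to compound 4 (within the scatter) is expected. That expectation rests on the earlier step of no change at the digits printed from compound 1 to compound 2 (within the scatter) and on the value of compound 3, 0%. Compound 4 is therefore estimated at 0%, with a range from -8% to 10%.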

Compound 4, a percentage reported as inhibition, at one concentration (the size of the read-out at that concentration, not a potency): 0%
The estimate for compound 4 equals the measured number at the digits printed; the range from low to high includes it.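

In this assay, among these compounds, fluoro in place of hydrogen on the phenylsulfanyl ring gives no change at the digits printed from compound 3 to compound 4 (within the scatter), and this agrees with the same change made earlier on the core without the 4-fluorobenzyl group: the same change on two cores in this assay, no change at the digits printed (within the scatter) from compound 1 to compound 2 and no change at the digits printed (within the scatter) from compound 3 to compound 4, 0 percentage points apart, within the scatter of two such steps Adding the 4-fluorobenzyl group to the fluorinated compound gives no change at the digits printed from compound 2 to compound 4 (within the scatter), which also agrees with the earlier step for that change: the same change on two cores in this assay, no change at the digits printed (within the scatter) from compound 1 to compound 3 and no change at the digits printed (within the scatter) from compound 2 to compound 4, 0 percentage points apart, within the scatter of two such steps Both changes therefore carry from one core to the other with the same result, but all four compounds show no inhibition, so this shows only that neither change brings detectable inhibition at the one concentration tested, not how either change would act on a compound that does inhibit the kinase.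

As far as these compounds go, whether an amine or a carboxylic acid in place of the fluoro, or a longer chain in place of the 4-fluorobenzyl group, would give any inhibition in this assay stays open. Also open, from the compounds shown here alone, is whether the two changes would still carry across cores once there is inhibition to gain or lose.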